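The source may hold more compounds than are shown below. What is called first, only, known or untested is meant among the compounds shown, and "the series" means these compounds.

Working notes on the series. In a functional assay on A549 cells (Homo sapiens) for cytotoxicity, read by XTT assay, with a stated time of 72 h (on this read-out higher numbers stand for weaker inhibition and lower numbers for stronger inhibition), compound 1 (`C=C1CC[C@H]2C(C)(C)CCC[C@]2(C)[C@H]1CC/C(C)=C/Cc1c(O)cc(O)c2c(=O)c(O)c(-c3ccc(O)cc3)oc12`) gives 32000 nM and compound 2 (`CC(C)=CCC/C=C(\C)Cc1c(O)cc(O)c2c(=O)c(OC/C=C(\C)CCC=C(C)C)c(-c3ccc(O)cc3)oc12`) gives 26000 nM. Compound 3 (`CC(=O)c1c(O)cc(O)c(CC=C(C)C)c1O`) gives 29000 nM, which lies within the scatter of both, so the three values cannot be ranked. Compound 4 (`CC(=O)c1c(O)c(CC=C(C)C)c(O)c(CC=C(C)C)c1O`) is compound 3 with 3-methylbut-2-en-1-yl in place of hydrogen on an aromatic carbon, ortho to two hydroxy groups and para to a hydroxy group (3-methylbut-2-en-1-yl in place of hydrogen on an aromatic carbon). For the measured compounds named here, no measured pair isolates this change, so there is no direct precedent for its size. The structures of compounds 1, 2 and 3 differ widely, yet their values stay within the scatter of one another, which argues against expecting a large move. A modest estimated shift towards stronger inhibition is expected, given as a 1.9-fold lower number from compound 3 to compound 4 (0.29 log units; within the scatter), though a result within the scatter would not surprise. For compound 4 the estimated value is 15000 nM, with an expected range of 5000 nM to 35000 nM.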

Compound 4, half-maximal inhibitory concentration: > 100000 nM
Compound 4 was reported as a limit; the forecaster's own chance of this, stated with the estimate: 15%; middle value at least 6.6-fold (0.82 log units) away from the limit.
By their numbers in this assay, from the lowest: compounds 2, 3 and 1 (each within the scatter of the next). At a limit, above all of these: compound 4.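

In this assay compound 4 gives > 100000 nM, which is a limit of the assay and not a number. Adding 3-methylbut-2-en-1-yl in place of hydrogen on the aromatic carbon ortho to two hydroxy groups and para to a hydroxy group weakens inhibition, with an at least 3.4-fold higher number from compound 3 to compound 4 (0.53 log units; beyond the scatter). Compounds 1, 2 and 3 lie within the scatter of one another and offer no comparison of a single change, so this aromatic carbon is the only position in the series where one substitution is seen to move the read-out.

Going by these compounds, the full size of the step stays open, as compound 4 is read only at a limit: the limit of > 100000 nM in this assay, at which 1 of the 4 values shown sits. Also open is whether a methyl group, an amine or a carboxylic acid on this aromatic carbon would shift the read-out in the same direction.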